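Exchanging Chloro for Bromo in Two Related Series

The compounds below may be only part of what the source reports. "The series", "measured", "known", "first", "only" and "open" are said of these compounds alone.

Three compounds have so far been measured in a functional assay on CCRF-CEM cells (Homo sapiens) for inhibition; a lower number here means a stronger inhibitor, a higher number a weaker inhibitor:

Compound 1, `O=C1/C(=C/c2cccc(Cl)c2)CCCc2ccccc21`, 9440 nM
Compound 2, `O=C1/C(=C/c2cccc(Br)c2)CCCc2ccccc21`, 8900 nM
Compound 3, `O=C1CCCCC/C1=C\c1ccc(Cl)cc1`, 43500 nM

Compound 1 and compound 2 share one core and differ only in the change (bromo in place of chloro on an aromatic carbon). The step that this change made is a 1.1-fold lower number from compound 1 to compound 2 (0.03 log units; within the scatter), so the two compounds cannot be told apart in this assay.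

Compound 3 is built on a different core from that of compound 1; how the two cores differ is not broken down here. What is clear is that compound 3 gives the highest number of the three, and its distance from both compound 1 and compound 2 lies beyond the scatter, so it is the weakest inhibitor of the measured set.

Compound 4, `O=C1CCCCC/C1=C\c1ccc(Br)cc1`, has not yet been measured. It differs from compound 3 by the change (bromo in place of chloro on an aromatic carbon). Going by the values given here, this is the same kind of change as the one between compound 1 and compound 2, but not the same: in compound 1 the halogen sits meta to a large group, whereas in compound 3 it sits para to a group of 9 heavy atoms.

Among the compounds with values here, since the only precedent for this exchange is the step from compound 1 to compound 2, compound 4 is expected to stay close to compound 3, and the estimated step of a 1.1-fold lower number from compound 3 to compound 4 (0.04 log units; within the scatter) rests on that precedent because a 1.1-fold lower number from compound 1 to compound 2 (0.03 log units; within the scatter) lay within the scatter. For compound 4 in this assay the estimate is 40000 nM, with a likely range from 18000 nM to 90000 nM.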

Compound 4, half-maximal inhibitory concentration: 42800 nM
Compound 4: middle estimate off by 1.1-fold (0.03 log units), on the low side, within the range that was stated.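

In this assay, the exchange of chloro for bromo on the second core gives a 1.0-fold lower number from compound 3 to compound 4 (0.01 log units; within the scatter), so the two compounds cannot be told apart. Set beside the earlier case, the exchange gives the same outcome on both cores, and the two steps cannot be separated: the same change on two cores in this assay, a 1.1-fold lower number (0.03 log units; within the scatter) from compound 1 to compound 2 and a 1.0-fold lower number (0.01 log units; within the scatter) from compound 3 to compound 4, 1.0-fold (0.02 log units) apart, within the scatter of two such steps. This shows that, for these two pairs, what was seen on the core of compound 1 carried over to the core of compound 3, with the halogen para to a group of 9 heavy atoms in the new pair; it does not show that the exchange would be equally silent on any further core of the series, and it gives no explanation of why the read-out stays level.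

The compounds shown carry only chloro or bromo as the halogen on the aromatic ring, so it remains open whether a fluoro group, a methoxy group or an amine at that place would move the number in this assay on either core. From the compounds shown here alone, it also remains open whether the level outcome of this exchange would hold on a core with a ring of another size.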